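A few compounds are considered here, and "the series" means these few. Any claim that something is new, unique, unknown or untested is made for them only; others in the source may bear on it.

Compound 1 `CC1CCN(C2CCN(S(=O)(=O)c3cn(C)c(=O)n(C)c3=O)CC2)CC1`: in a functional assay on DLD-1 cells (Homo sapiens) for antiproliferative activity, read by CellTiter-Glo, with a stated time of 72 h (a lower number here means a stronger inhibitor, a higher number a weaker inhibitor), compound 1 gives only a limit, > 5000 nM.
Compound 2 `Cc1ccc(S(=O)(=O)N2CCC(N3CCC(C)CC3)CC2)cc1C`: in this assay compound 2 gives 24 nM.

Compound 2 stands as the only measured number shown in this assay. Compound 1 sits at the assay limit, (the limit of > 5000 nM in this assay, at which 1 of the 2 values shown sits), and nothing more can be read from it. Among the compounds with values here, no two measured compounds here differ in a single place, so no measured step is available to lean on.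

Compound 3 `Cc1nc(Cl)sc1S(=O)(=O)N1CCC(N2CCC(C)CC2)CC1` differs from compound 2 by 2-chloro-4-methyl-1,3-thiazol-5-yl in place of 3,4-dimethylphenyl on a sulfonyl sulfur: the sulfonamide nitrogen in a ring and the rest of the shared core are kept, and the change is confined to the aryl group on the sulfonyl sulfur.

Without a measured step of this kind, the expected step in this assay is a 2.5-fold higher number from compound 2 to compound 3 (0.40 log units; beyond the scatter), a modest loss that may well stay within the scatter. Compound 3 is accordingly estimated at 60 nM, with a range from 15 nM to 300 nM.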

Compound 3, half-maximal inhibitory concentration: 1.6 nM
For compound 3 the middle estimate is 38-fold (1.57 log units) above the measured one, and the stated range ends above it.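

In this assay, the aryl group on the sulfonyl sulfur turns out to be a place where one replacement moves the number strongly: putting 2-chloro-4-methyl-1,3-thiazol-5-yl in place of 3,4-dimethylphenyl gives a 15-fold lower number from compound 2 to compound 3 (1.18 log units; beyond the scatter). A six-membered aromatic ring of carbon only is therefore not required here, since a five-membered aromatic ring with 2 hetero atoms serves, and compound 3 is the stronger inhibitor of this pair. Nothing measured here accounts for the gain.

The step changes the ring, the chlorine and the methyl groups together, so the compounds shown do not tell which of them carries the gain. On these data alone, it also remains open how the number would respond to a thiazol-5-yl group carrying hydrogen, fluorine or a nitrile in place of the chlorine.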